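The source may report more compounds than this note shows. Statements on the series, on what has been measured and on what is new or still open speak of the compounds shown alone.

Measured in a functional assay on HeLa cells (Homo sapiens) for cytotoxicity, read by MTT assay, with a stated time of 48 h; on this read-out higher numbers stand for weaker inhibition and lower numbers for stronger inhibition:
compound 1 `O=C1C(O)=C(C(c2ccc(F)cc2)c2c[nH]c3ccccc23)C(=O)c2ccccc21`: 15800 nM
compound 2 `COc1ccc(C(C2=C(O)C(=O)c3ccccc3C2=O)c2c[nH]c3ccccc23)cc1Br`: 7320 nM
compound 3 `O=C1C(O)=C(C(c2cccs2)c2c[nH]c3ccccc23)C(=O)c2ccccc21`: 12400 nM

Compound 3 gives the second highest of the three numbers in this assay; the steps to its neighbours, a 1.3-fold lower number from compound 1 to compound 3 (0.11 log units; within the scatter) and a 1.7-fold higher number from compound 2 to compound 3 (0.23 log units; within the scatter), both lie within the scatter, so no order among these is claimed. Compound 4 `O=C1C(O)=C(C(c2cccc([N+](=O)[O-])c2)c2c[nH]c3ccccc23)C(=O)c2ccccc21` carries 3-nitrophenyl in place of thiophen-2-yl on a saturated chain carbon bound to an aromatic carbon and a double-bonded ring carbon. Within the data shown here, the steps that bear on this swap are the three aryl exchanges at the same position: a 2.2-fold lower number from compound 1 to compound 2 (0.33 log units; beyond the scatter) is modest yet beyond the scatter, while a 1.3-fold lower number from compound 1 to compound 3 (0.11 log units; within the scatter) and a 1.7-fold higher number from compound 2 to compound 3 (0.23 log units; within the scatter) are not. On that basis a step of at most modest size is expected in this assay for compound 4, most likely none beyond the scatter, a 1.2-fold lower number from compound 3 to compound 4 (0.09 log units; within the scatter). Compound 4 is therefore estimated at 10000 nM, within 4000 nM to 25000 nM.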

Compound 4, half-maximal inhibitory concentration: 24900 nM
Beside the measured number, compound 4's estimate is 2.5-fold (0.40 log units) below it; the range from low to high includes it.
By their numbers in this assay, from the lowest: compounds 2, 3, 1 and 4 (each within the scatter of the next, the first and the last beyond it).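

In this assay the aryl exchanges at this saturated chain carbon now span a wider range: a 3.4-fold higher number from compound 2 to compound 4 (0.53 log units; beyond the scatter) is the largest step yet, though still modest. The 3-nitrophenyl group separates only from the 3-bromo-4-methoxyphenyl group, with a 2.0-fold higher number from compound 3 to compound 4 (0.30 log units; within the scatter) and a 1.6-fold higher number from compound 1 to compound 4 (0.20 log units; within the scatter) both inside the scatter. No measurement on hand accounts for this step.

From the compounds shown here alone, whether the bromine or the methoxy group of compound 2 carries its separation stays open. So does the effect of a non-aromatic group at this carbon, such as an amine, a carboxylic acid or a longer chain.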